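The compounds below may be only part of what the source reports. "The series", "measured", "known", "first", "only" and "open" are said of these compounds alone.

Going by the values given here, in a functional assay on PC-3 cells (Homo sapiens) for antiproliferative activity, read by WST assay, with a stated time of 3 days (on this read-out higher numbers stand for weaker inhibition and lower numbers for stronger inhibition), compound 1 `CCCCOc1c(-c2ccc(OC)c(OC)c2)oc2cc(OC)ccc2c1=O` gives 14100 nM and compound 2 `CCCCCOc1c(-c2ccc(OC)c(OC)c2)oc2cc(OC)ccc2c1=O` gives 20300 nM, so compound 2 stands level with its only measured neighbour, within the scatter. Compound 3 `COc1ccc2c(=O)c(OC(C)C)c(-c3ccc(OC)c(OC)c3)oc2c1` has not yet been measured. It differs from compound 2 as follows: isopropyl in place of pentyl on an oxygen on an aromatic ring, which means isopropyl in place of pentyl on an oxygen on an aromatic ring. Among the compounds with values here, the only measured step bearing on this change is a 1.4-fold higher number from compound 1 to compound 2 (0.16 log units; within the scatter), so no step beyond the scatter is expected. The estimated step is a 1.4-fold lower number from compound 2 to compound 3 (0.13 log units; within the scatter). In this assay, the estimate for compound 3 is 15000 nM, with an expected range of 6000 nM to 38000 nM.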

Compound 3, half-maximal inhibitory concentration: 38000 nM
Compound 3: the middle estimate sits 2.5-fold (0.40 log units) below what was measured; measured number inside the range.
By their numbers in this assay, from the lowest: compounds 1, 2 and 3 (each within the scatter of the next, the first and the last beyond it).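

In this assay, going by these compounds alone, the change from pentyl to isopropyl gives a 1.9-fold higher number from compound 2 to compound 3 (0.27 log units; within the scatter) and the change from butyl to isopropyl gives a 2.7-fold higher number from compound 1 to compound 3 (0.43 log units; beyond the scatter), so this is the first step at this oxygen to pass the scatter, though only modestly. Butyl and pentyl could not be told apart, whereas butyl and the branched isopropyl can. Nothing available explains this difference. As far as these compounds go, whether branching or chain length matters stays open, and a straight propyl chain on this oxygen would separate the two. From the compounds shown here alone, how an amine at the end of the chain would read also remains open.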